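The source may report more compounds than this note shows. Statements on the series, on what has been measured and on what is new or still open speak of the compounds shown alone.

Three analogues of the shared core carry the measurement. Compound 1 `COc1cccc(Nc2nccc(-c3cccs3)n2)c1` gives 900 nM in a functional assay for inhibition, with Homo sapiens as the target; a higher number here means a weaker inhibitor, a lower number a stronger inhibitor. Compound 2 `COc1ccc(Nc2nccc(-c3cccs3)n2)cc1` gives 3900 nM in this assay. Compound 3 `CC1CCN(c2ccc(Nc3nccc(-c4cccs4)n3)cc2)CC1` gives 400 nM in this assay, the lowest of the three numbers; compound 1 lies nearest and compound 2 furthest, both gaps beyond the scatter.

Going by the values given here, the one single-point step measured so far runs from the methoxy of compound 2 to the 4-methylpiperidin-1-yl of compound 3: a 9.8-fold lower number from compound 2 to compound 3 (0.99 log units; beyond the scatter).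

Compound 4 `c1ccc(Nc2nccc(-c3cccs3)n2)cc1` is not yet measured. Its structural change from compound 3 is hydrogen in place of 4-methylpiperidin-1-yl on an aromatic carbon. The position is the same aromatic carbon, described as para to a large group, at which the methoxy of compound 2 and the 4-methylpiperidin-1-yl of compound 3 sit. Among the compounds with values here, the step from compound 2 to compound 3 shows that filling this position with the larger group lowered the number; removing the group altogether has no measured counterpart, so the size of the reverse is uncertain, and the methoxy of compound 2 may or may not be a fair stand-in for hydrogen.

For compound 4 the expected change is a 6.3-fold higher number from compound 3 to compound 4 (0.80 log units; beyond the scatter), a rise in the number, because the step from compound 2 to compound 3 a 9.8-fold lower number from compound 2 to compound 3 (0.99 log units; beyond the scatter) points that way. The estimate for compound 4 in this assay is 2500 nM, with a range from 900 nM to 7000 nM.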

Compound 4, half-maximal inhibitory concentration: 31700 nM
The estimate for compound 4 lay 13-fold (1.10 log units) below the measured number, outside the stated range (above it).
By their numbers in this assay, from the lowest: compound 3; then compound 1; then compound 2; then compound 4.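

Notes on the aromatic carbon para to a large group: in this assay, hydrogen at this carbon gives by far the highest number of the series, and taking away the 4-methylpiperidin-1-yl costs much more than the earlier compounds suggested (a 79-fold higher number from compound 3 to compound 4 (1.90 log units; beyond the scatter)). Methoxy also proves no stand-in for hydrogen (an 8.1-fold higher number from compound 2 to compound 4 (0.91 log units; beyond the scatter)), and the methoxy of compound 1 likewise stands well below the unsubstituted compound (a 35-fold higher number from compound 1 to compound 4 (1.55 log units; beyond the scatter)), so all three substituted compounds lie below compound 4, with none going against this among the four shown. Nothing available accounts for the size of these steps or for the order among the substituents.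

The compounds shown do not separate the contribution of the ring nitrogen from that of the carbon framework and the 4-methyl group of the 4-methylpiperidin-1-yl, so a plain piperidine, a morpholine or an open-chain dimethylamino group at this carbon would be the informative comparison. From the compounds shown here alone, how a carboxylic acid or a longer alkyl chain would behave at this carbon also remains open, as does whether the rise seen on going to hydrogen holds for other groups.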